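Bromo to Methyl on a Shared Core: Expected Cell Toxicity

The compounds below may be only part of what the source reports. "The series", "measured", "known", "first", "only" and "open" are said of these compounds alone.

Three close relatives of one shared core have been examined in an ADME assay on HEK293 cells (Homo sapiens) for cytotoxicity, read by MTT assay, with a stated time of 36 h; on this read-out lower numbers stand for stronger inhibition and higher numbers for weaker inhibition. Compound 1 `O=C(c1ccc2c(c1)OCCO2)C1CCN(Cc2coc(-c3ccc(F)cc3)n2)CC1` carries a fluoro on an aromatic carbon, compound 2 `O=C(c1ccc2c(c1)OCCO2)C1CCN(Cc2coc(-c3ccc(Br)cc3)n2)CC1` carries a bromo at that spot, and compound 3 `O=C(c1ccc2c(c1)OCCO2)C1CCN(Cc2coc(-c3ccccc3)n2)CC1` carries hydrogen there. In this assay compound 1 gives > 150 ug/mL, which is a limit of the assay rather than a number. Compound 2 gives > 150 ug/mL in this assay, again only a limit. Compound 3 gives > 150 ug/mL in this assay, also a limit. Compound 2 thus stands exactly where its two neighbours stand, at the limit of > 150 ug/mL in this assay, at which 3 of the 3 values shown sit.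

The measured changes tell little about size: bromo for fluoro gave a step that the two limits leave unreadable from compound 1 to compound 2, hydrogen for fluoro gave a step that the two limits leave unreadable from compound 1 to compound 3, and hydrogen for bromo gave a step that the two limits leave unreadable from compound 2 to compound 3.

Compound 4 `Cc1ccc(-c2nc(CN3CCC(C(=O)c4ccc5c(c4)OCCO5)CC3)co2)cc1` differs from compound 2 by methyl in place of bromo on an aromatic carbon; cut one bond further out, the same difference reads 4-bromophenyl to 4-methylphenyl. Among the compounds with values here, since every measured step is unreadable, the only guide is that all three values sit at the limit. Compound 4 is therefore expected to show an essentially flat step that the limit leaves unreadable from compound 2 to compound 4. Compound 4 is estimated at 200 ug/mL, within 100 ug/mL to 400 ug/mL, in this assay.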

Compound 4, half-maximal inhibitory concentration: > 150 ug/mL
Compound 4 gave a limit, no number; the forecaster's own chance of this, stated with the estimate: 85%; the middle value is on the limit's open side.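

In this assay, within the data shown here, compound 4 also gives a limit rather than a number, so no step between compound 4 and compound 1, compound 2 or compound 3 can be read: the limit of > 150 ug/mL in this assay, at which 4 of the 4 values shown sit. The compounds shown leave open whether fluoro, bromo, hydrogen or methyl at this spot makes any difference to cell toxicity.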